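Moving the Trifluoromethyl Group: From Compound 2 to Compound 3

A few compounds are considered here, and "the series" means these few. Any claim that something is new, unique, unknown or untested is made for them only; others in the source may bear on it.

Compound 2 `COc1cc(C2=NN(C(C)=O)C(c3ccccc3C(F)(F)F)O2)cc(OC)c1OC` gives 31.8% in a functional assay on BGC-823 cells (Homo sapiens) for antiproliferative activity, read by MTT assay, tested at 1 uM (a higher number here means a stronger effect of the compound at the concentration tested, a lower number a weaker effect), the higher of the two numbers recorded. Compound 1 `COc1cc(C(=O)N/N=C/c2cccc(F)c2)cc(OC)c1OC` gives 13.6% in this assay, a gap beyond the usual scatter. Compound 3 `COc1cc(C2=NN(C(C)=O)C(c3cccc(C(F)(F)F)c3)O2)cc(OC)c1OC` has not been measured and differs from compound 2 in one respect: 3-(trifluoromethyl)phenyl in place of 2-(trifluoromethyl)phenyl on a saturated ring carbon. Among the compounds with values here, no measured pair shows a change of this kind, so the direction of the step cannot be read from the data. The step of a number 1.8 percentage points lower from compound 2 to compound 3 (within the scatter) is expected to remain within the scatter. Compound 3 is therefore estimated at 30%, with a range from 10% to 55%.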

Compound 3, a percentage reported as inhibition, at one concentration (the size of the read-out at that concentration, not a potency): 27.9%
For compound 3 the middle estimate is 2.1 percentage points above the measured one; the measured number falls inside the stated range.
By their numbers in this assay, from the lowest: compound 1; then compounds 3 and 2 (each within the scatter of the next).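

Placing 3-(trifluoromethyl)phenyl in place of 2-(trifluoromethyl)phenyl on the saturated ring carbon gives a number 3.9 percentage points lower from compound 2 to compound 3 (within the scatter) in this assay. Within the data shown here, this is the first pair to test this position, and on this read-out at this single concentration, the two placements of the trifluoromethyl group cannot be told apart. No available data offer an explanation for this result. The compounds shown leave open how this read-out would respond to an amine or a carboxylic acid on this phenyl ring, or to a longer chain in place of the acetyl group.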